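Nitrooxy Ester Chain Length Against HeLa Cytotoxicity

The source may hold more compounds than are shown below. What is called first, only, known or untested is meant among the compounds shown, and "the series" means these compounds.

Compound 1 `COc1cc(/C=C/C(=O)OC(C)C)ccc1O` gives 31100 nM in a functional assay on HeLa cells (Homo sapiens) for cytotoxicity, read by resazurin assay, with a stated time of 72 h; on this read-out lower numbers stand for stronger inhibition and higher numbers for weaker inhibition.
Compound 2 `COc1cc(/C=C/C(=O)OCCCO[N+](=O)[O-])ccc1O` gives 6700 nM in this assay.

For the measured compounds named here, compound 2 holds the lowest of the two numbers; its only neighbour is compound 1, reached by a 4.6-fold lower number from compound 1 to compound 2 (0.67 log units; beyond the scatter). Compound 3 `COc1cc(/C=C/C(=O)OC/C=C/CO[N+](=O)[O-])ccc1O` differs from compound 2 by a group of 7 heavy atoms (3 carbon, 1 nitrogen, 3 oxygen; no ring) in place of a group of 6 heavy atoms (2 carbon, 1 nitrogen, 3 oxygen; no ring), on a saturated chain carbon bound to an oxygen next to a carbonyl group. Going by the values given here, the single measured step, a 4.6-fold lower number from compound 1 to compound 2 (0.67 log units; beyond the scatter), concerned replacing isopropyl with the nitrooxy chain itself, not lengthening that chain, so it bears only indirectly here and no step in this assay tests this change. A step within the scatter is expected. Compound 3 is therefore estimated at 6000 nM, between 2500 nM and 14000 nM. That estimate means a 1.1-fold lower number from compound 2 to compound 3 (0.05 log units; within the scatter).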

Compound 3, half-maximal inhibitory concentration: 1000 nM
The estimate for compound 3 lay 6.0-fold (0.78 log units) above the measured number, outside the stated range (below it).
By their numbers in this assay, from the lowest: compound 3; then compound 2; then compound 1.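

The earlier step showed only that a nitrooxy chain in place of isopropyl lowers the number; this one shows that, on a saturated chain carbon bound to an oxygen next to a carbonyl group, the form of that chain matters too. In this assay, replacing 2-(nitrooxy)ethyl with the group of 7 heavy atoms and one more double bond gives a 6.7-fold lower number from compound 2 to compound 3 (0.83 log units; beyond the scatter). Nothing shown here accounts for this difference.

The compounds shown leave open whether the extra carbon or the double bond carries the change, which a longer saturated chain would help separate. They also leave open whether a hydroxyl in place of the nitrooxy group on the same chain would give a similar number.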